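Alpha-keto heterocycles against diacylglycerol lipase-alpha: working notes

A few compounds are considered here, and "the series" means these few. Any claim that something is new, unique, unknown or untested is made for them only; others in the source may bear on it.

Measured so far, each in an assay on HEK-293T cells for inhibition of diacylglycerol lipase-alpha (Homo sapiens), read by colorimetric assay; a lower number here means a stronger inhibitor, a higher number a weaker inhibitor:
- compound 1 `O=C(CCCCCCc1ccccc1)c1nncs1` gives > 10000 nM, a limit of the assay.
- compound 2 `O=C(CCCCCCc1ccccc1)c1nnc(-c2cccs2)s1` gives > 10000 nM, a limit of the assay.
- compound 3 `O=C(CCCCCCc1ccccc1)c1nnc(-c2ccccc2)s1` gives > 10000 nM, a limit of the assay.

Compound 1 stands only at a limit in this assay, and the two other values are limits as well, so its place among them cannot be read. The steps a step that the two limits leave unreadable from compound 1 to compound 2, a step that the two limits leave unreadable from compound 1 to compound 3 and a step that the two limits leave unreadable from compound 2 to compound 3 are all unreadable, the reason being (the limit of > 10000 nM in this assay, at which 3 of the 3 values shown sit).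

The next compound, compound 4 `O=Cc1coc(C(=O)CCCCCCc2ccccc2)n1`, differs from compound 1 by 4-formyl-1,3-oxazol-2-yl in place of 1,3,4-thiadiazol-2-yl on a carbonyl carbon. Among the measured compounds shown here, none of the measured steps touches the core heterocycle itself; all three vary only the group on an aromatic carbon of the shared core, and none gives a readable size. The direction of the step in this assay therefore rests on nothing measured here. Compound 4 is estimated at 500 nM, with a range from 40 nM to 10000 nM. That estimate means a step of an at least 20-fold lower number from compound 1 to compound 4 (1.30 log units; beyond the scatter), with wide uncertainty and a real chance that only a limit is returned.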

Compound 4, half-maximal inhibitory concentration: 1510 nM
Estimate against measurement, compound 4: 3.0-fold (0.48 log units) below; the measured number falls inside the stated range.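

Among the compounds shown here, compound 4 gives the first number in this assay that is not a limit, so the group on the carbonyl carbon is the first place where a change can be read. Exchanging 1,3,4-thiadiazol-2-yl for 4-formyl-1,3-oxazol-2-yl, with the saturated chain kept, gives an at least 6.6-fold lower number from compound 1 to compound 4 (0.82 log units; beyond the scatter). That size is only a lower bound, since compound 1 stands at a limit: the limit of > 10000 nM in this assay, at which 3 of the 4 values shown sit.

The exchange alters the five-membered aromatic ring and adds the formyl group in one step, so the compounds shown do not separate the two contributions. Open too, from the compounds shown here alone, is whether the same ring without the formyl group, or with a carboxylic acid or an amide in its place, would keep a readable number.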